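Ester-bearing side chains on the shared core: toxicity notes

The compounds below may be only part of what the source reports. "The series", "measured", "known", "first", "only" and "open" are said of these compounds alone.

Measured so far:
compound 1 `CCOC(=O)NC(=O)NC1=CS(=O)(=O)O[C@@]12[C@@H](CO[Si](C)(C)C(C)(C)C)O[C@@H](n1cc(C)c(=O)n(C)c1=O)[C@@H]2O[Si](C)(C)C(C)(C)C`: 3000 nM
compound 2 `COC(=O)CNC1=CS(=O)(=O)O[C@@]12[C@@H](CO[Si](C)(C)C(C)(C)C)O[C@@H](n1cc(C)c(=O)n(C)c1=O)[C@@H]2O[Si](C)(C)C(C)(C)C`: 96000 nM

In a functional assay on CCRF-CEM cells (Homo sapiens) (on this read-out higher numbers stand for lower toxicity in this test and lower numbers for higher toxicity in this test), compound 1 gives the lowest number of the two, compound 2 giving a 32-fold higher number from compound 1 to compound 2 (1.51 log units; beyond the scatter). Compound 3 `Cc1cn([C@@H]2O[C@H](CO[Si](C)(C)C(C)(C)C)[C@@]3(OS(=O)(=O)C=C3NCC(=O)OCc3ccccc3)[C@H]2O[Si](C)(C)C(C)(C)C)c(=O)n(C)c1=O` is unmeasured; its change from compound 1 is (benzyloxycarbonyl)methyl in place of (ethoxycarbonyl)carbamoyl on an amine nitrogen. For the measured compounds named here, the only comparable step is the one to compound 2, where a (methoxycarbonyl)methyl group also took the place of the (ethoxycarbonyl)carbamoyl group and gave a 32-fold higher number from compound 1 to compound 2 (1.51 log units; beyond the scatter); the benzyl ester in compound 3 is untested. A large rise of similar size is therefore expected, a 20-fold higher number from compound 1 to compound 3 (1.30 log units; beyond the scatter). For compound 3 the estimate in this assay is 60000 nM, within 15000 nM to 200000 nM.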

Compound 3, half-maximal cytotoxic concentration: 250000 nM
The estimate for compound 3 lay 4.2-fold (0.62 log units) below the measured number, and the stated range ends below it.
By their numbers in this assay, from the lowest: compound 1; then compound 2; then compound 3.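

In this assay, the large rise on leaving the (ethoxycarbonyl)carbamoyl group recurs with a second ester-bearing side chain (an 83-fold higher number from compound 1 to compound 3 (1.92 log units; beyond the scatter)), so at this amine nitrogen it no longer rests on compound 2 alone. Phenyl in place of hydrogen on the saturated chain carbon adds a modest further step (a 2.6-fold higher number from compound 2 to compound 3 (0.42 log units; beyond the scatter)). No evidence bears on the cause of either step.

Open: whether a free carboxylic acid in place of the ester keeps these high numbers, and whether a longer chain between the amine nitrogen and the carbonyl does.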